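This account rests on a few compounds, and the source may have more. Where it says the series, first, only, none or still open, it means among the compounds named here.

Compound 1 `CC(C)COc1ncc(-c2cn(C)c3cc(C(=O)NS(C)(=O)=O)ccc23)cc1Cl` gives < 15 nm/s in an ADME assay on Caco-2 cells (Homo sapiens) for permeability, in the apical to basolateral direction; on this read-out higher numbers stand for higher permeability and lower numbers for lower permeability; this is a limit of the assay, not a number.
Compound 2 `Cn1cc(-c2ccc(C(F)F)cc2)c2cc(F)c(C(=O)NS(=O)(=O)C3CC3)cc21` gives 81 nm/s in this assay.
Compound 3 `CC(C)COc1ccc(-c2nn(C)c3cc(C(=O)NS(=O)(=O)C4CC4)c(F)cc23)cn1` has no result in this assay: "not determined" (no result reported).

Among these three entries compound 2 therefore stands as the only one with an actual number. The entry for compound 1 is a limit only, (the limit of < 15 nm/s in this assay, at which 1 of the 3 values shown sits). Compound 3 has no single number at all, so nothing can be said of it beyond that.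

Compound 4 `Cn1cc(-c2ccc(C(F)(F)F)cc2)c2cc(F)c(C(=O)NS(=O)(=O)C3CC3)cc21` differs from compound 2 in one place only: fluoro in place of hydrogen on a saturated chain carbon bound to an aromatic carbon and two fluorine atoms. Within the data shown here, no pair of measured compounds shows this same change, so the expectation for compound 4 rests on compound 2 alone and on the small size of the change. In this assay the step of a 1.2-fold higher number from compound 2 to compound 4 (0.09 log units; within the scatter) is expected to be small, with neither direction favoured clearly enough to reach beyond the usual scatter of repeated measurements. Compound 4 is accordingly estimated at 100 nm/s, with a range running from 40 nm/s to 250 nm/s.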

Compound 4, apparent permeability: 46 nm/s
For compound 4 the middle estimate is 2.2-fold (0.34 log units) above the measured one; measured number inside the range.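

Among these compounds, this is the first step between two measured compounds that differ in one place, so 4-(difluoromethyl)phenyl can now be compared directly with 4-(trifluoromethyl)phenyl in this assay. Fluoro in place of hydrogen on this saturated chain carbon gives a 1.8-fold lower number from compound 2 to compound 4 (0.25 log units; within the scatter), so this single change does not separate the two compounds by more than repeated measurements of the same compound might. Nothing measured here speaks to the reason for this step.

The compounds shown leave open whether a different group on the phenyl ring in this place, such as a nitrile or a primary amine, would also stay this close to compound 2. Among the compounds shown here, they also leave open whether difluoromethyl to trifluoromethyl would give a similar step on another core, as only this one pair carries the change.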